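Methyl in Place of Methoxy: What to Expect for Compound 4

The source may report more compounds than this note shows. Statements on the series, on what has been measured and on what is new or still open speak of the compounds shown alone.

Measured compounds:
compound 1 `Nc1ccccc1NC(=O)c1ccc(CSc2nccc(C(F)(F)F)n2)cc1`: 1140 nM
compound 2 `Nc1ccccc1NC(=O)/C=C/c1ccc(CSc2ccc(F)cc2)cc1`: "not determined" (no result reported)
compound 3 `COc1ccc(SCc2ccc(C(=O)Nc3ccccc3N)cc2)cc1`: 2390 nM

Two of these three compounds have a number in a functional assay on HeLa cells (Homo sapiens) for antiproliferative activity, read by CCK-8 assay, with a stated time of 72 h; a lower number here means a stronger inhibitor, a higher number a weaker inhibitor. In this assay compound 1 gives 1140 nM. For compound 2 no result was reported. In this assay compound 3 gives 2390 nM, the highest of the two numbers, and its gap to compound 1 lies beyond the usual scatter.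

Compound 4 `Cc1ccc(SCc2ccc(C(=O)Nc3ccccc3N)cc2)cc1` differs from compound 3 in one place: methyl in place of methoxy on an aromatic carbon. Among the measured compounds shown here, no measured pair shows this change, so the direction is open. A small group swaps for a smaller one at the same place, and the expected step of a 1.1-fold lower number from compound 3 to compound 4 (0.04 log units; within the scatter) stays within the scatter, in no clear direction. Compound 4 is thus expected to give about 2200 nM, within a range of 800 nM to 6000 nM.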

Compound 4, half-maximal inhibitory concentration: 4250 nM
The estimate for compound 4 lay 1.9-fold (0.29 log units) below the measured number, within the range that was stated.
By their numbers in this assay, from the lowest: compound 1; then compounds 3 and 4 (each within the scatter of the next).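

In this assay, replacing 4-methoxyphenyl with 4-methylphenyl gives a 1.8-fold higher number from compound 3 to compound 4 (0.25 log units; within the scatter). Among the compounds shown here, this is the first measured pair at this position, and it shows that removing the oxygen, with its one hydrogen-bond acceptor, gives no step beyond the scatter, so the two compounds cannot be ranked. No available measurement speaks to the reason for this result. The compounds shown leave open whether an amine or a carboxylic acid at this same place on the shared core would produce a step beyond the scatter, and in which direction.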